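Compound 3 and the Stability of Compound 2

A few compounds are considered here, and "the series" means these few. Any claim that something is new, unique, unknown or untested is made for them only; others in the source may bear on it.

Measured so far in an ADME assay on microsomes from liver (Rattus norvegicus) for metabolic stability, using NADPH, with a stated time of 10 min (on this read-out lower numbers stand for a less stable compound and higher numbers for a more stable compound), are two compounds
- Compound 1 (`NCCCCN(C[C@@H]1Cc2ncccc2CN1)[C@H]1CCCc2cccnc21`) with 55%
- Compound 2 (`CN(C)CCCCN(C[C@H]1Cc2ncccc2CN1)[C@H]1CCCc2cccnc21`) with 27%

Of these two, compound 2 holds the lower number, at 27% against compound 1 with 55% and this gap lies beyond the usual scatter of repeated measurements. A higher number here means that more of the compound survives the incubation.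

The next compound to be measured is compound 3 (`c1cnc2c(c1)CN[C@@H](CN(CCCC1CCNCC1)[C@H]1CCCc3cccnc31)C2`). It differs from compound 2 by a single change (piperidin-4-yl in place of (dimethylamino)methyl on a saturated chain carbon, three bonds along the chain from an amine nitrogen) in which piperidin-4-yl stands in place of (dimethylamino)methyl on a saturated chain carbon, three bonds along the chain from an amine nitrogen. Cut one bond further out, the same change reads 4-(dimethylamino)butyl to 3-(piperidin-4-yl)propyl.

Going by the values given here, no measured pair shows this change, so the expectation is loose. Compound 2 at 27% and compound 1 at 55% set the only span available in this assay and a value within it is expected. An upward step is expected, estimated as a number 13 percentage points higher from compound 2 to compound 3 (beyond the scatter) and modest in size. Compound 3 is estimated at 40% (expected range 20% to 62%).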

Compound 3, percent of the compound remaining: 40%
For compound 3 middle estimate and measured number coincide at the digits printed, and the stated range covers the measured number.
By their numbers in this assay, from the lowest: compound 2; then compound 3; then compound 1.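

Going by these compounds alone, this is the first single change that can be read on its own in this assay: piperidin-4-yl in place of (dimethylamino)methyl on a saturated chain carbon, three bonds along the chain from an amine nitrogen, gives a number 13 percentage points higher from compound 2 to compound 3 (beyond the scatter). This place on the chain therefore accepts a six-membered non-aromatic ring carrying a hydrogen-bond donor, and more of the compound remains after incubation, not less. No measurement that could account for this step is available, so its origin remains unknown.

A single pair also cannot show which part of the change goes with the step, as the ring and the added hydrogen-bond donor enter together, and the larger group adds heavy atoms as well. On these data alone, a 1-methylpiperidin-4-yl group at the same place would keep the ring without that donor, while a longer chain or a morpholin-4-yl group would test other features, and how any of these would read in this assay remains open.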